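A few compounds are considered here, and "the series" means these few. Any claim that something is new, unique, unknown or untested is made for them only; others in the source may bear on it.

Of the compounds shown here, two have so far been measured in a toxicity assay on the whole organism (strain Icem-CET (SPF Caw)) for cytotoxicity, with Mus musculus as the target; a higher number here means that more compound is needed for the effect, a lower number that less compound is needed. Compound 1, with the structure `C#CCNC(=O)/C(C)=C(\C)c1ccc(Cl)cc1`, gives 200 mg/kg in this assay. Compound 2, with the structure `C=CCNC(=O)/C(C)=C(\C)c1ccc(OC)cc1`, gives 300 mg/kg in this assay. These two numbers lie within the usual scatter of each other, so on what has been measured compound 2 cannot be set apart from compound 1 in either direction. Compound 3, with the structure `C=CCNC(=O)/C(C)=C(\C)c1ccc(Cl)cc1`, has not yet been measured in this assay. It differs from compound 2 in one place: chloro in place of methoxy on an aromatic carbon. Going by the values given here, no pair of measured compounds differs by this single change, so there is no measured step to lean on. Compound 1 does carry the chloro group, with a different chain on the amide, and its value of 200 mg/kg sits within the scatter of compound 2, which suggests that the dose for compound 3 will stay close by. The expected step from compound 2 to compound 3 in this assay, a 1.3-fold lower number from compound 2 to compound 3 (0.12 log units; within the scatter), is therefore small and not beyond the scatter. Compound 3 is estimated at 230 mg/kg, with a range from 120 mg/kg to 450 mg/kg.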

Compound 3, dose for half-maximal effect: 70 mg/kg
The estimate for compound 3 lay 3.3-fold (0.52 log units) above the measured number, outside the stated range (below it).
By their numbers in this assay, from the lowest: compound 3; then compounds 1 and 2 (each within the scatter of the next).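

In this assay, going by these compounds alone, the aromatic carbon para to a large group turns out to be a sensitive place: chloro in place of methoxy gives a 4.3-fold lower number from compound 2 to compound 3 (0.63 log units; beyond the scatter), a change beyond the scatter that the earlier compounds could not show. The chain on the amide nitrogen also counts, since with chloro held fixed, vinyl in place of ethynyl gives a 2.9-fold lower number from compound 1 to compound 3 (0.46 log units; beyond the scatter), so compound 3 needs the least compound for the effect among the three, and two single changes each separate it from a neighbour. No independent measurement is available to explain either step.

Only methoxy and chloro are shown on the aromatic ring, so it remains open whether a fluoro, bromo or methyl group there would follow chloro or methoxy, and whether the chloro-for-methoxy step would be the same size with the ethynyl chain of compound 1 in place of vinyl. Equally open, as far as these compounds go, is how a saturated propyl chain or a longer chain on the amide nitrogen would compare with the vinyl chain of compound 3.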